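A few compounds are considered here, and "the series" means these few. Any claim that something is new, unique, unknown or untested is made for them only; others in the source may bear on it.

Compound 1, with the structure `C[Se]c1nc([Se]C)c2cccnc2n1`, was put through a functional assay on MCF7 cells (Homo sapiens) for cytotoxicity, read by MTT assay, with a stated time of 72 h (on this read-out higher numbers stand for lower toxicity in this test and lower numbers for higher toxicity in this test), where compound 1 is recorded as "not determined" (no result reported), so it stands without a number of its own. Two related compounds give an idea of the range seen here. Compound 2, with the structure `CCCCC[Se]c1nc(NCc2ccccc2)c2ccccc2n1`, gives 99400 nM in this assay. Compound 3, with the structure `CSc1nc(NCCCCc2ccccc2)c2ccccc2n1`, gives 95900 nM in this assay. These two values fall within the usual scatter of one another, so they show the same weak toxicity rather than any difference between them.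

Compound 4, with the structure `C[Se]c1nc(N)c2cccnc2n1`, has not yet been measured. It differs from compound 1 in one place: one nitrogen atom in place of a group of 2 heavy atoms (1 carbon, 1 selenium; no ring), on an aromatic carbon. Among the compounds with values here, no measured pair in this set makes the same change, so there is no step from which to read its effect. Within the data shown here, with compound 1 itself unmeasured, and the only numbers at hand coming from compound 2 and compound 3, the expectation for compound 4 can rest only on that weak range; no direction can be claimed, and any shift could well lie within the scatter. On that basis, compound 4 is estimated at 100000 nM in this assay, with a likely range from 30000 nM to 300000 nM.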

Compound 4, concentration lethal to 50% of the cells: > 100000 nM
Compound 4: no number, only a limit (the forecaster's own chance of this, stated with the estimate: 35%); the middle value lies on the limit itself.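

Within the data shown here, compound 1 has no number in this assay, and compound 4 gives > 100000 nM, which is a limit rather than a number, so no step between these two compounds can be read. The compounds shown leave open whether replacing a group of 2 heavy atoms with amino on this core changes the toxicity to these cells at all.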